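Selenium isothiourea series: benzyl to methyl on selenium

The source may report more compounds than this note shows. Statements on the series, on what has been measured and on what is new or still open speak of the compounds shown alone.

Among the compounds with values here, compound 2 `O=C(/N=C(/NC(=O)c1ccno1)[Se]Cc1ccccc1)c1ccno1` is the only member of this set with a number rather than a limit in a functional assay on K562 cells (Homo sapiens) for cytotoxicity, read by MTT assay, with a stated time of 72 h; on this read-out higher numbers stand for weaker inhibition of growth and lower numbers for stronger inhibition of growth; in this assay compound 2 gives 20000 nM. Compound 1 `CS/C(=N\C(=O)c1ccno1)NC(=O)c1ccno1` reaches only a limit: in this assay compound 1 gives > 100000 nM, which is the limit of the measurement and not a number (the limit of > 100000 nM in this assay, at which 1 of the 2 values shown sits). Within the data shown here, the one measured step, an at least 5.0-fold lower number from compound 1 to compound 2 (0.69 log units; beyond the scatter), swaps both the chalcogen and the benzyl group at once, so it bears only partly on the change now in question. Compound 3 `C[Se]/C(=N\C(=O)c1ccno1)NC(=O)c1ccno1` differs from compound 2 by hydrogen in place of phenyl on a saturated chain carbon bound to a selenium atom, keeping selenium. Removing the phenyl moves the structure back toward compound 1, whose value sits at the limit, so a weaker result is expected. The expected step is a 3.0-fold higher number from compound 2 to compound 3 (0.48 log units; beyond the scatter). Compound 3 is estimated at 60000 nM, between 20000 nM and 200000 nM.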

Compound 3, concentration for 50% growth inhibition: 870 nM
Compound 3: middle estimate off by 69-fold (1.84 log units), on the high side, outside the stated range (below it).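

Notes on the group on selenium: in this assay, going from benzyl to methyl (a 23-fold lower number from compound 2 to compound 3 (1.36 log units; beyond the scatter)) shows that the phenyl on a saturated chain carbon bound to a selenium atom is not required for growth inhibition, and that the smaller group gives the stronger result in this pair. With methyl held constant, the sulfur to selenium swap (an at least 110-fold lower number from compound 1 to compound 3 (2.06 log units; beyond the scatter)) isolates the chalcogen, which the earlier step could not do because it also changed the methyl to benzyl. The value of compound 1 is a limit and not a number, so this step has a lower bound only: the limit of > 100000 nM in this assay, at which 1 of the 3 values shown sits.

The compounds shown leave open whether an ethyl group or a longer chain on selenium would keep the strength of compound 3. Also open, going by these compounds, is how a chain ending in an amine or a carboxylic acid would compare.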